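The source may hold more compounds than are shown below. What is called first, only, known or untested is meant among the compounds shown, and "the series" means these compounds.

Compound 1, with the structure `C=CCc1ccc(OCc2cn(-c3ccccc3Cl)nn2)c(O)c1`, and compound 2, with the structure `C=CCc1ccc(OCc2cn(-c3ccc(C(=O)c4ccccc4)cc3)nn2)c(O)c1`, share one core and differ only in the aryl group carried on the triazole. Both were tested in a functional assay on MIA PaCa-2 cells (Homo sapiens) for inhibition, read by MTT assay, with a stated time of 72 h, tested at 50 uM; on this read-out lower numbers stand for less inhibition of growth and higher numbers for more inhibition of growth at the one concentration tested. In this assay compound 1 gives 57.7%. In this assay compound 2 gives 53.7%. Among the compounds with values here, compound 2 thus stands alongside compound 1: the two numbers lie within the usual scatter of each other, so nothing separates them on this read-out, and no step between them is reported.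

Compound 3, with the structure `C=CCc1ccc(OCc2cn(-c3ccc(Br)cc3)nn2)c(O)c1`, has not yet been measured in this assay. Compared with compound 2 it differs in one place: bromo in place of benzoyl on an aromatic carbon. Both measured compounds, carrying different groups on that same aryl ring, give much the same number, which gives no ground to expect a shift beyond the scatter. The step from compound 2 to compound 3 is therefore expected to be small, a number 1.3 percentage points higher from compound 2 to compound 3 (within the scatter), with no clear direction. Compound 3 is expected to give about 55% in this assay, with a likely range from 40% to 70%.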

Compound 3, percent growth inhibition at one concentration: 47.3%
Compound 3: middle estimate off by 7.7 percentage points, on the high side; the measured number falls inside the stated range.
By their numbers in this assay, from the lowest: compounds 3, 2 and 1 (each within the scatter of the next, the first and the last beyond it).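

In this assay, the step of a number 6.4 percentage points lower from compound 2 to compound 3 (within the scatter) shows that the whole benzoyl, with its six-membered aromatic ring, can give way to a single bromo on this aromatic carbon, para to a large group, without a change that stands clear of the scatter. Within the data shown here, the swap of 2-chlorophenyl for 4-bromophenyl on the aromatic nitrogen gives a number 10.4 percentage points lower from compound 1 to compound 3 (beyond the scatter), the first step beyond the scatter, though only a modest one, and it alters both the halogen and where it sits on the ring, so these two changes cannot be told apart here. Nothing available bears on the reason for either step.

A 4-chlorophenyl or a 2-bromophenyl group on the same nitrogen would separate the halogen from its place on the ring, and the compounds shown include neither. It also remains open how an amine, a carboxylic acid or a methoxy group on the carbon that carries the bromo in compound 3 would read in this assay, and how any of these compounds would behave at concentrations other than the single one tested.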